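The source may report more compounds than this note shows. Statements on the series, on what has been measured and on what is new or still open speak of the compounds shown alone.

Compound 1 `N[C@H]1CC[C@H](Nc2c(C(=O)NCc3ccc(F)cc3)nc(N3CCCCC3)c3cccnc23)CC1` belongs to a small set examined for growth inhibition of a breast cancer cell line. In a functional assay on MCF7 cells (Homo sapiens) for cytotoxicity, read by MTT assay, with a stated time of 72 h (on this read-out higher numbers stand for weaker inhibition and lower numbers for stronger inhibition), compound 1 gives 5000 nM, and this is the only plain number shown for the set. Compound 2 `CS(=O)(=O)NCCCN(c1nc(C(=O)NCc2ccc(F)cc2)c(O)c2ncccc12)S(C)(=O)=O` does not yield a number at all: in this assay compound 2 gives > 20000 nM, which is a limit of the assay rather than a measurement. Compound 1 therefore stands alone as the measured point, with one further entry sitting at the limit of > 20000 nM in this assay, at which 1 of the 2 values shown sits. Compound 3 `N[C@H]1CC[C@H](Nc2c(C(=O)NCc3ccc(F)cc3)nc(N3CCCCS3(=O)=O)c3cccnc23)CC1` is not yet measured. It differs from compound 1 in one place: a group of 8 heavy atoms (4 carbon, 1 nitrogen, 2 oxygen, 1 sulfur; one six-membered non-aromatic ring with 2 hetero atoms) in place of a group of 6 heavy atoms (5 carbon, 1 nitrogen; one six-membered non-aromatic ring with 1 hetero atom), on an aromatic carbon. Within the data shown here, no step between measured compounds exists, so nothing in the data fixes how large this change should be. The step expected is a 1.6-fold higher number from compound 1 to compound 3 (0.20 log units; within the scatter), a modest shift toward weaker inhibition that may not exceed the scatter. Compound 3 is estimated to give 8000 nM in this assay, within a range from 3000 nM to 25000 nM.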

Compound 3, half-maximal inhibitory concentration: 13000 nM
Estimate against measurement, compound 3: 1.6-fold (0.21 log units) below, and the stated range covers the measured number.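

In this assay, among these compounds, the first step between measured compounds puts a size on a change at this place, the aromatic carbon next to the ring nitrogen and para to the (4-aminocyclohexyl)amino group: a 2.6-fold higher number from compound 1 to compound 3 (0.41 log units; beyond the scatter). Replacing the piperidin-1-yl ring with the larger six-membered ring bearing sulfur and two oxygens thus moves the number toward weaker inhibition by a modest step, and compound 3 still gives a plain number rather than a limit. Nothing measured in this set bears on why the number shifts.

With a single replacement at this place, the compounds shown leave open whether the shift follows the sulfur, its two oxygens or the larger group. They also leave open how a morpholin-4-yl ring or an open-chain amine such as diethylamino would compare there.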